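This account rests on a few compounds, and the source may have more. Where it says the series, first, only, none or still open, it means among the compounds named here.

Measured so far:
Compound 1 `CN(C)CC1CCC/C(=C\c2ccc(OC(=O)/C=C/c3ccc(F)cc3)cc2)C1=O`: 6000 nM
Compound 2 `CN(C)CC1CCC/C(=C\c2ccc(OC(=O)/C=C/c3ccc(Br)cc3)cc2)C1=O`: 4440 nM

In a functional assay on CCRF-CEM cells (Homo sapiens) (on this read-out higher numbers stand for weaker inhibition and lower numbers for stronger inhibition), compound 2 gives 4440 nM, which lies within the scatter of compound 1 at 6000 nM. Compound 3 `CN(C)CC1CCC/C(=C\c2ccc(OC(=O)c3ccccc3)cc2)C1=O` has not yet been measured. It differs from compound 2 as follows: phenyl in place of 2-(4-bromophenyl)ethenyl on a carbonyl carbon. For the measured compounds named here, the only measured step, a 1.4-fold lower number from compound 1 to compound 2 (0.13 log units; within the scatter), swaps fluoro for bromo and leaves the 2-(4-bromophenyl)ethenyl group's chain in place, so it bears on this change only weakly. With no measured guide to size or direction, the expected step is a 1.1-fold higher number from compound 2 to compound 3 (0.05 log units; within the scatter), none beyond the scatter, though with wide uncertainty. The estimate for compound 3 is 5000 nM, expected between 1500 nM and 16000 nM.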

Compound 3, half-maximal inhibitory concentration: 29400 nM
Compound 3: middle estimate off by 5.9-fold (0.77 log units), on the low side; the measured number lies above the stated range.
By their numbers in this assay, from the lowest: compounds 2 and 1 (each within the scatter of the next); then compound 3.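

In this assay, the group on this carbonyl carbon matters: phenyl in place of 2-(4-bromophenyl)ethenyl gives a 6.6-fold higher number from compound 2 to compound 3 (0.82 log units; beyond the scatter) and phenyl in place of 2-(4-fluorophenyl)ethenyl gives a 4.9-fold higher number from compound 1 to compound 3 (0.69 log units; beyond the scatter) as a second step beyond the scatter. The swap of halogen alone had stayed within the scatter, while these changes remove the ethenyl link and the halogen together. Nothing available accounts for this shift.

The compounds shown leave open which of the two removed parts carries the difference. An unsubstituted 2-phenylethenyl group or a 4-bromophenyl group on the same carbon would separate them.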